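Amine tail variation on the shared core, outlook for compound 4

The compounds below may be only part of what the source reports. "The series", "measured", "known", "first", "only" and "open" are said of these compounds alone.

Among the compounds with values here, compound 3 `CN(C)CCCCn1c2c(c3ccccc31)C(=O)c1c[n+]([O-])c3ccccc3c1C2=O` gives 310 nM in a functional assay on A549 cells (Homo sapiens) for cytotoxicity, read by MTT assay, with a stated time of 72 h (on this read-out lower numbers stand for stronger inhibition and higher numbers for weaker inhibition), and so shows the lowest number of the three measured so far. Compound 2 `O=C1c2c[n+]([O-])c3ccccc3c2C(=O)c2c1c1ccccc1n2CCCCN1CCNCC1` gives 540 nM in this assay, and the step of a 1.7-fold lower number from compound 2 to compound 3 (0.24 log units; within the scatter) stays within the scatter. Compound 1 `O=C1c2c[n+]([O-])c3ccccc3c2C(=O)c2c1c1ccccc1n2Cc1cn(CC(O)CO)nn1` gives 880 nM in this assay, the other two steps being a 2.8-fold lower number from compound 1 to compound 3 (0.45 log units; beyond the scatter) and a 1.6-fold lower number from compound 1 to compound 2 (0.21 log units; within the scatter) on the same read-out. Compound 4 `CCCN1CCN(CCCCn2c3c(c4ccccc42)C(=O)c2c[n+]([O-])c4ccccc4c2C3=O)CC1` is not yet measured and differs from compound 3 by 4-propylpiperazin-1-yl in place of dimethylamino on a saturated chain carbon, four bonds along the chain from an aromatic nitrogen on the same chain. Within the data shown here, because the reverse of a 1.7-fold lower number from compound 2 to compound 3 (0.24 log units; within the scatter) is the only measured step that bears on this change, the step of a 1.4-fold higher number from compound 3 to compound 4 (0.13 log units; within the scatter) is expected to stay within the scatter. Compound 4 is therefore expected to give 420 nM in this assay, with 200 nM and 900 nM as its range.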

Compound 4, half-maximal inhibitory concentration: 320 nM
Compound 4: middle estimate off by 1.3-fold (0.12 log units), on the high side; measured number inside the range.
By their numbers in this assay, from the lowest: compounds 3, 4, 2 and 1 (each within the scatter of the next, the first and the last beyond it).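

In this assay, the step of a 1.0-fold higher number from compound 3 to compound 4 (0.01 log units; within the scatter) shows that this position accepts 4-propylpiperazin-1-yl as readily as dimethylamino. Propyl on the ring amine nitrogen gives a 1.7-fold lower number from compound 2 to compound 4 (0.23 log units; within the scatter), so this substitution is also not separated from the hydrogen form. With a 2.8-fold lower number from compound 1 to compound 4 (0.44 log units; beyond the scatter), a second amine tail stands beyond the scatter of the triazole tail of compound 1, as compound 3 already did.

A morpholine ring or a carboxylic acid at this chain end remains open, and no measurement shown gives a reason for these steps.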